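Swapping fluoro for nitro on the cinnamoyl tail

This account rests on a few compounds, and the source may have more. Where it says the series, first, only, none or still open, it means among the compounds named here.

Compounds measured so far:
- compound 1 `COc1ccc(C(=O)c2cc(OC)c(OC)c(OC)c2)cc1N`: 30 nM
- compound 2 `COc1cccc(/C=C/C(=O)Nc2cc(OC)c(OC)c(OC)c2)c1`: 8500 nM
- compound 3 `COc1ccc(C(=O)c2cc(OC)c(OC)c(OC)c2)cc1NC(=O)/C=C/c1ccc(F)cc1`: 400 nM

All three were tested in a functional assay on B16 cells (Mus musculus) for cytotoxicity, read by MTT assay, with a stated time of 72 h; on this read-out higher numbers stand for weaker inhibition and lower numbers for stronger inhibition. Among them compound 3 holds the second highest number. Going by the values given here, compound 1, which carries a free amine in place of the larger side chain, gives a lower number, and the only measured single-point change, a 13-fold higher number from compound 1 to compound 3 (1.12 log units; beyond the scatter), describes exactly that gap. Compound 2 lacks the central carbonyl bridge altogether and gives the highest number of the set.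

The next compound, compound 4 `COc1ccc(C(=O)c2cc(OC)c(OC)c(OC)c2)cc1NC(=O)/C=C/c1ccc([N+](=O)[O-])cc1`, differs from compound 3 in one spot: nitro in place of fluoro on an aromatic carbon, para to a large group. Among the compounds with values here, no measured pair among the three shows a change at this position, so none of the recorded steps speaks directly to it; the one recorded step concerns adding the whole side chain, not altering its far end. With nothing to indicate a shift in either direction, the expectation is for a step of no change at the digits printed from compound 3 to compound 4 (within the scatter), that is, no change beyond the usual scatter. For compound 4 the estimated value in this assay is therefore 400 nM, with a plausible range from 130 nM to 1200 nM.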

Compound 4, half-maximal inhibitory concentration: 6400 nM
The estimate for compound 4 lay 16-fold (1.20 log units) below the measured number, outside the stated range (above it).
By their numbers in this assay, from the lowest: compound 1; then compound 3; then compounds 4 and 2 (each within the scatter of the next).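

In this assay the far end of the side chain proves not to be a silent position: nitro in place of fluoro on an aromatic carbon, para to a large group, gives a 16-fold higher number from compound 3 to compound 4 (1.20 log units; beyond the scatter) with the rest of the structure unchanged. The earlier step (a 13-fold higher number from compound 1 to compound 3 (1.12 log units; beyond the scatter)) concerned adding the whole side chain, so it could not show that a single group at the end of that chain can, on its own, produce a large step. Nitro brings three heavy atoms and two hydrogen-bond acceptors where fluoro brought one heavy atom and none, but no supporting measurement ties the step to either count or to any other feature of the swap.

The compounds shown leave open whether this large step is particular to nitro or would also appear with another group on the same carbon, such as an amine, a methoxy group, chloro or plain hydrogen. With only fluoro and nitro at this position, this single pair cannot establish a trend across groups, and it also leaves open how nitro would fare at other places on the same ring.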